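The compounds below may be only part of what the source reports. "The series", "measured", "known", "first", "only" and "open" are said of these compounds alone.

Compound 1 `CCN(CC)CCn1cnnc1-c1cc(Oc2ccc(NC(=O)Nc3ccc(Cl)c(C(F)(F)F)c3)cc2F)ccn1` gives 900 nM in a functional assay on HT-29 cells (Homo sapiens) for antiproliferative activity, read by MTT assay, with a stated time of 72 h; on this read-out lower numbers stand for stronger inhibition and higher numbers for weaker inhibition. Compound 2 `CCN(CC)CCn1cnnc1-c1cc(Oc2ccc(NC(=O)Nc3cccc(C(F)(F)F)c3)cc2F)ccn1` differs from it by hydrogen in place of chloro on an aromatic carbon and gives 630 nM in this assay, a step of a 1.4-fold lower number from compound 1 to compound 2 (0.15 log units; within the scatter). Compound 3 `CN(C)CCCn1cnnc1-c1cc(Oc2ccc(NC(=O)Nc3ccc(Cl)c(C(F)(F)F)c3)cc2F)ccn1` carries a different core, differing from compound 1 by (dimethylamino)methyl in place of diethylamino on a saturated chain carbon, two bonds along the chain from an aromatic nitrogen; in this assay compound 3 gives 1400 nM, a step of a 1.6-fold higher number from compound 1 to compound 3 (0.19 log units; within the scatter). Compound 4 `CN(C)CCCn1cnnc1-c1cc(Oc2ccc(NC(=O)Nc3cccc(C(F)(F)F)c3)cc2F)ccn1` is not yet measured and differs from compound 3 by hydrogen in place of chloro on an aromatic carbon, the same change as from compound 1 to compound 2, at the same place. The step from compound 3 to compound 4 is expected to resemble the earlier one, a 1.4-fold lower number from compound 3 to compound 4 (0.15 log units; within the scatter), because that earlier step was a 1.4-fold lower number from compound 1 to compound 2 (0.15 log units; within the scatter) and lay within the scatter. Compound 4 is therefore estimated at 1000 nM, expected between 500 nM and 2100 nM.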

Compound 4, half-maximal inhibitory concentration: 980 nM
For compound 4 the middle estimate is 1.0-fold (0.01 log units) above the measured one; the measured number falls inside the stated range.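

In this assay, going by these compounds alone, going from 4-chloro-3-(trifluoromethyl)phenyl to 3-(trifluoromethyl)phenyl gives a 1.4-fold lower number from compound 3 to compound 4 (0.15 log units; within the scatter), matching the step on the core of compound 1: the same change on two cores in this assay, a 1.4-fold lower number (0.15 log units; within the scatter) from compound 1 to compound 2 and a 1.4-fold lower number (0.15 log units; within the scatter) from compound 3 to compound 4, 1.0-fold (0.00 log units) apart, within the scatter of two such steps The side-chain change gives a 1.6-fold higher number from compound 2 to compound 4 (0.19 log units; within the scatter), matching its earlier step: the same change on two cores in this assay, a 1.6-fold higher number (0.19 log units; within the scatter) from compound 1 to compound 3 and a 1.6-fold higher number (0.19 log units; within the scatter) from compound 2 to compound 4, 1.0-fold (0.00 log units) apart, within the scatter of two such steps Every step here lies within the scatter, so the match shows only that both changes stay small on these two cores; it does not show that either change truly shifts activity, and two pairs set no rule for other cores.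

As far as these compounds go, whether a step beyond the scatter would carry over in the same way remains open, for instance with a nitrile or methoxy group in place of chloro. Also open, from the compounds shown here alone, is how a side chain ending in morpholine or piperidine would behave.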